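Swapping a propyl for 2-chlorophenyl on a kinase inhibitor core

This account rests on a few compounds, and the source may have more. Where it says the series, first, only, none or still open, it means among the compounds named here.

Measured so far:
Compound 1, `CN1CC(=O)N(C)c2cnc(Nc3ccc(S(N)(=O)=O)cc3)nc21`: 495 nM
Compound 2, `CCCC1C(=O)N(C)c2cnc(Nc3ccc(S(N)(=O)=O)cc3)nc2N1C`: 206 nM

Both compounds were tested in an assay on Sf9 cells for inhibition of serine/threonine-protein kinase 4 (Homo sapiens), read by luminescence and ADP-Glo, with a stated time of 1 h, in the presence of a further agent that is not named here; a lower number here means a stronger inhibitor, a higher number a weaker inhibitor. Compound 1 gives 495 nM, and compound 2 gives 206 nM. Of the two numbers, compound 2 is the lower: the step of a 2.4-fold lower number from compound 1 to compound 2 (0.38 log units; beyond the scatter) goes beyond the usual scatter, so compound 2 is the stronger inhibitor of the pair.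

Compound 3, `CN1C(=O)C(c2ccccc2Cl)N(C)c2nc(Nc3ccc(S(N)(=O)=O)cc3)ncc21`, has not yet been measured. It differs from compound 2 in one place: 2-chlorophenyl in place of propyl on a saturated ring carbon. Among the measured compounds shown here, the only measured step that touches this ring carbon is a 2.4-fold lower number from compound 1 to compound 2 (0.38 log units; beyond the scatter), where a propyl entered in place of hydrogen and the number fell modestly. For the measured compounds named here, that step shows the position tolerates a group of some size, but it says nothing about an aromatic ring with a chlorine; nothing measured so far carries such a group there. The expectation for compound 3 is therefore a small step at most, a 1.4-fold lower number from compound 2 to compound 3 (0.14 log units; within the scatter), with the direction left open. Compound 3 is estimated at 150 nM, between 40 nM and 600 nM.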

Compound 3, half-maximal inhibitory concentration: 129 nM
Estimate against measurement, compound 3: 1.2-fold (0.07 log units) above, and the stated range covers the measured number.
By their numbers in this assay, from the lowest: compounds 3 and 2 (each within the scatter of the next); then compound 1.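

In this assay, the saturated ring carbon that bears a propyl in compound 2 also accepts a 2-chlorophenyl, which has 7 heavy atoms against 3 and brings a six-membered aromatic ring. The swap gives a 1.6-fold lower number from compound 2 to compound 3 (0.20 log units; within the scatter) and so does not separate the two groups. Measured against hydrogen, the change gives a 3.8-fold lower number from compound 1 to compound 3 (0.58 log units; beyond the scatter), which shows that a substituent with an aromatic ring at this carbon, like the ringless propyl, goes with a stronger inhibitor than compound 1. No information is available on why two such different groups give numbers this close.

The compounds shown leave open what the chlorine itself contributes, as a plain phenyl is not among them, and whether moving the chlorine to another ring carbon would matter. They also give no reading in this assay for an amine, a carboxylic acid or a chain longer than propyl on this same carbon.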